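The compounds below may be only part of what the source reports. "The series", "measured", "known", "first", "only" and "open" are said of these compounds alone.

Compound 1 `CC1(C)CC(NC(=O)Nc2ccccc2)c2cc(Cl)ccc2O1` serves as the reference point of this account, yet in a functional assay on B16-F10 cells (Mus musculus) for inhibition, read by MTT assay, with a stated time of 72 h (on this read-out lower numbers stand for stronger inhibition and higher numbers for weaker inhibition), compound 1 is reported as "not determined" (no result reported), so it stands on no number at all. Among the compounds with values here, the only measured member of the set is compound 2 `CC1(C)CC(NC(=S)Nc2ccc(Cl)cc2)c2cc(Br)ccc2O1`, which in this assay gives 7000 nM. Within the data shown here, compound 2 shares only part of its make-up with compound 1, and no step between the two is recorded. Compound 3 `CC1(C)CC(NC(=O)Nc2ccccc2Cl)c2cc(Cl)ccc2O1` is the compound still to be measured. It differs from compound 1 in one place: chloro in place of hydrogen on an aromatic carbon. Among the measured compounds shown here, with no value for compound 1 and no recorded step in this assay, neither the size nor the direction of the change can be read from any measured pair; the expectation can rest only on the single value of compound 2 and is therefore wide. Compound 3 is expected to give about 8000 nM in this assay, within a range of 2000 nM to 40000 nM.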

Compound 3, half-maximal inhibitory concentration: 20000 nM
Compound 3: middle estimate off by 2.5-fold (0.40 log units), on the low side, and the stated range covers the measured number.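

In this assay compound 3 gives 20000 nM while compound 1 gives "not determined" (no result reported) and so no new step can be read between them. The compounds shown leave open what chloro in place of hydrogen does to inhibition. No measured evidence bears on this result.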